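The source may hold more compounds than are shown below. What is called first, only, known or untested is meant among the compounds shown, and "the series" means these compounds.

In a functional assay on DU-145 cells (Homo sapiens) for inhibition, read by trypan blue exclusion, with a stated time of 96 h (a higher number here means a weaker inhibitor of growth, a lower number a stronger inhibitor of growth), compound 2 `CCOc1cc(/C=C(\C(=O)c2ccc(Cl)cc2)S(=O)(=O)Cc2ccc(Cl)cc2)ccc1O` gives 10000 nM, the higher of the two numbers, while compound 1 `COc1ccccc1/C=C(\C(=O)c1ccc(Cl)cc1)S(=O)(=O)c1ccc(C)cc1` gives 1000 nM, a gap beyond the scatter. Compound 3 `COc1ccccc1/C=C(\C(=O)c1ccc(Cl)cc1)S(=O)(=O)Cc1ccc(Cl)cc1` carries 2-methoxyphenyl in place of 3-ethoxy-4-hydroxyphenyl on a double-bonded chain carbon bound to a double-bonded chain carbon. Going by the values given here, no measured pair isolates this change. Among the compounds with values here, the only guide is compound 1, which also carries 2-methoxyphenyl but differs elsewhere and gives 1000 nM. In this assay, a sizeable move towards stronger inhibition is therefore expected, with an estimated 6.7-fold lower number from compound 2 to compound 3 (0.82 log units; beyond the scatter). The expected value for compound 3 is 1500 nM, with an estimated range of 300 nM to 7000 nM.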

Compound 3, concentration for 50% growth inhibition: 25000 nM
The estimate for compound 3 lay 17-fold (1.22 log units) below the measured number; measured number above the stated range.
By their numbers in this assay, from the lowest: compound 1; then compound 2; then compound 3.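

In this assay, 2-methoxyphenyl in place of 3-ethoxy-4-hydroxyphenyl on a double-bonded chain carbon bound to a double-bonded chain carbon weakens growth inhibition (a 2.5-fold higher number from compound 2 to compound 3 (0.40 log units; beyond the scatter)), so 2-methoxyphenyl does not by itself bring the stronger number of compound 1. With 2-methoxyphenyl held fixed, 4-chlorobenzyl in place of 4-methylphenyl on a sulfonyl sulfur gives the larger move (a 25-fold higher number from compound 1 to compound 3 (1.40 log units; beyond the scatter)). No measurement here accounts for either step. From the compounds shown here alone, whether 3-ethoxy-4-hydroxyphenyl would also fare better with 4-methylphenyl on the sulfonyl sulfur remains open. So does the effect of an amine or a carboxylic acid on that aromatic ring.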